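This account rests on a few compounds, and the source may have more. Where it says the series, first, only, none or still open, it means among the compounds named here.

Measured so far in an assay on isolated protein for inhibition of protein kinase C theta type (Homo sapiens), read by TR-FRET, with a stated time of 2 h; a lower number here means a stronger inhibitor, a higher number a weaker inhibitor:
compound 1, `CO[C@H]1CC[C@@H](CNc2cc(NCc3cnccc3C(F)(F)F)ncc2C#N)CC1`, gives 70 nM
compound 2, `N#Cc1cnc(NCc2ccccc2)cc1N[C@H]1CC[C@@H](O)CC1`, gives 7000 nM
compound 3, `N#Cc1cnc(NCc2cncnc2-c2ccccc2)cc1N[C@H]1CC[C@@H](O)CC1`, gives 90 nM

Compound 1 gives the lowest number of the three. Compound 3 sits close to it, within the usual scatter, so the two cannot be told apart; compound 2 stands far higher, well beyond the scatter. The next compound, compound 4, `CC1(C)C[C@@H](Nc2cc(NCc3cnccc3C(F)(F)F)ncc2C#N)CC[C@@H]1O`, keeps the shared core of compound 1 and changes the group on one ring nitrogen: 4-hydroxy-3,3-dimethylcyclohexyl in place of (4-methoxycyclohexyl)methyl on a nitrogen on an aromatic ring. Within the data shown here, no measured pair shows this change on its own. Since compounds 2 and 3 carry a hydroxy-bearing ring joined directly to that nitrogen and compound 3 gives 90 nM, a modest step, expected at a 1.6-fold higher number from compound 1 to compound 4 (0.20 log units; within the scatter), seems most likely, possibly within the scatter. Compound 4 is therefore estimated at 110 nM, within 30 nM to 400 nM.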

Compound 4, half-maximal inhibitory concentration: 120 nM
Beside the measured number, compound 4's estimate is 1.1-fold (0.04 log units) below it; low and high end bracket the measured number.
By their numbers in this assay, from the lowest: compounds 1, 3 and 4 (each within the scatter of the next); then compound 2.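

Putting 4-hydroxy-3,3-dimethylcyclohexyl in place of (4-methoxycyclohexyl)methyl on this nitrogen gives a 1.7-fold higher number from compound 1 to compound 4 (0.23 log units; within the scatter) and so the two compounds cannot be told apart. With the rest of the molecule unchanged, this position takes either group with no clear difference in the number, even though the entering group adds a hydrogen-bond donor and joins its ring directly to the nitrogen. No measurement here explains this result.

From the compounds shown here alone, the hydroxy group, the two methyl groups and the direct ring attachment all arrive in one change, so their separate contributions remain open. Going by these compounds, how an amine or a carboxylic acid on this ring would read also remains open.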